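The source may hold more compounds than are shown below. What is called first, only, known or untested is meant among the compounds shown, and "the series" means these compounds.

Measured compounds:
compound 1 `COc1cc(CNC(=O)/C=C/c2ccccc2)ccc1O` — 3660 nM
compound 2 `COc1cc(CNC(=O)/C=C/c2ccccc2)ccc1OCc1nc(C)c(C)nc1C` — 7310 nM
compound 3 `COc1cc(CNC(=O)/C=C/c2ccc(OC)c(OCc3nc(C)c(C)nc3C)c2)ccc1O` — 9250 nM

In a functional assay on SH-SY5Y cells (Homo sapiens) for cytotoxicity, read by MTT assay, with stated times of 24 h and 4 h (on this read-out higher numbers stand for an effect only at larger amounts of compound and lower numbers for an effect already at smaller amounts), compound 2 holds the second highest of the three numbers, and both other values lie within the scatter of it: a 2.0-fold higher number from compound 1 to compound 2 (0.30 log units; within the scatter), while compound 3 differs from compound 2 by less still. Compound 4 `COc1ccc(/C=C/C(=O)NCc2ccc(OCc3nc(C)c(C)nc3C)c(OC)c2)cc1OC` arises from compound 2 by 3,4-dimethoxyphenyl in place of phenyl on a double-bonded chain carbon bound to a double-bonded chain carbon. Among the compounds with values here, no measured step changes that same position in one place; only compound 3, which also carries substituents on the ring bound to the double-bonded chain carbon, speaks to it, and its value sits close to compound 2. Compound 4 is therefore expected to show no change beyond the scatter, a 1.1-fold higher number from compound 2 to compound 4 (0.04 log units; within the scatter), and is estimated at 8000 nM, within 4000 nM to 16000 nM.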

Compound 4, half-maximal effective concentration: 4470 nM
Compound 4: middle estimate off by 1.8-fold (0.25 log units), on the high side, within the range that was stated.
By their numbers in this assay, from the lowest: compounds 1, 4, 2 and 3 (each within the scatter of the next, the first and the last beyond it).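

In this assay, within the data shown here, a 1.6-fold lower number from compound 2 to compound 4 (0.21 log units; within the scatter) is the first reading of this position with only this group exchanged, since compound 3 differs from compound 2 in more than one place. Exchanging phenyl for 3,4-dimethoxyphenyl on this chain carbon therefore gives no difference beyond the scatter. Nothing given here offers an explanation for this result. From the compounds shown here alone, whether a phenyl ring carrying an amine or a carboxylic acid at this place would give a difference beyond the scatter remains open. So does whether the same exchange would read alike on the core of compound 1.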